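Ethyl ester in place of free acid: compound 4

A few compounds are considered here, and "the series" means these few. Any claim that something is new, unique, unknown or untested is made for them only; others in the source may bear on it.

Going by the values given here, compound 3 `O=C(O)C1=Cc2ccccc2OC1(OCc1cc(-c2ccc(F)cc2)no1)C(F)(F)F` gives 64200 nM in a functional assay on MCF7 cells (Homo sapiens) for inhibition, read by MTT assay, with a stated time of 24 h (on this read-out higher numbers stand for weaker inhibition and lower numbers for stronger inhibition), and is the only compound of the set with a number rather than a limit. Compound 1 `CCOC(=O)C1=Cc2ccccc2OC1(OCc1cc(-c2ccc(F)cc2F)no1)C(F)(F)F` sits at the limit > 150000 nM in this assay. Compound 2 `CCOC(=O)C1=Cc2ccccc2OC1(OCc1cc(-c2ccc(OC)cc2)no1)C(F)(F)F` also sits at the limit > 150000 nM in this assay. The step that the two limits leave unreadable from compound 1 to compound 2 is therefore unreadable. Compound 4 `CCOC(=O)C1=Cc2ccccc2OC1(OCc1cc(-c2ccc(F)cc2)no1)C(F)(F)F` differs from compound 3 by ethyl in place of hydrogen on an oxygen next to a carbonyl group. Among the compounds with values here, no measured step covers this change; what bears on it is the limit of > 150000 nM in this assay, at which 2 of the 3 values shown sit, where both ethyl esters sit while compound 3, the acid, alone gives a number. The expected step of a 3.1-fold higher number from compound 3 to compound 4 (0.49 log units; beyond the scatter) points toward weaker inhibition, beyond the scatter. Compound 4 is expected to give 200000 nM, within 60000 nM to 600000 nM, most likely reported again as a limit.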

Compound 4, half-maximal inhibitory concentration: 48200 nM
Estimate against measurement, compound 4: 4.1-fold (0.62 log units) above, outside the stated range (below it).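

In this assay, ethyl in place of hydrogen on an oxygen next to a carbonyl group gives a 1.3-fold lower number from compound 3 to compound 4 (0.12 log units; within the scatter), so at this position an ethyl ester can read the same as the free acid. The aromatic substituent now separates the ethyl esters: fluoro in place of methoxy gives an at least 3.1-fold lower number from compound 2 to compound 4 (0.49 log units; beyond the scatter), and hydrogen in place of fluoro gives an at least 3.1-fold lower number from compound 1 to compound 4 (0.49 log units; beyond the scatter). Both steps rest on limits rather than numbers for compound 1 and compound 2: the limit of > 150000 nM in this assay, at which 2 of the 4 values shown sit.

Open, going by these compounds, is how an amide or a longer ester chain would read at this position. Also open, on these data alone, is whether the free acid reads the same with the methoxy or difluoro aromatic substitution.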